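This account rests on a few compounds, and the source may have more. Where it says the series, first, only, none or still open, it means among the compounds named here.

Compound 1 `CCOC(=O)C1=C(C)N/C(=C/c2cc(C)n(-c3cccc(C(F)(F)F)c3)c2C)C1=O`: 2.1 ug/mL
Compound 2 `CCOC(=O)C1=C(C)N/C(=C/c2cc(C)n(-c3ccc(N(C)C)cc3)c2C)C1=O`: < 1.6 ug/mL

Both measured compounds were read in a physicochemical assay for solubility, read by nephelometry, in phosphate buffer, measured as kinetic solubility, at pH 6.5; on this read-out lower numbers stand for lower solubility and higher numbers for higher solubility. Compound 1 gives 2.1 ug/mL. For compound 2 the read-out is only a limit, < 1.6 ug/mL, and the limit of < 1.6 ug/mL in this assay, at which 1 of the 2 values shown sits, marks it as such. Among the measured compounds shown here, the single measured step, an at least 1.3-fold lower number from compound 1 to compound 2 (0.11 log units; that floor lies within the scatter), is therefore known only from one side, and its floor does not leave the usual scatter. Compound 2 thus stands without a number of its own, only a limit.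

Compound 3 `CCOC(=O)C1=C(C)N/C(=C/c2cc(C)n(-c3cccnc3)c2C)C1=O` has not yet been measured. It differs from compound 2 in one place: pyridin-3-yl in place of 4-(dimethylamino)phenyl on an aromatic nitrogen. For the measured compounds named here, the one measured step bears on this change in that it, too, swaps the group carried on the same aromatic nitrogen, compound 1 holding a 3-(trifluoromethyl)phenyl there; that step was small or unresolved. For compound 3 the expectation in this assay is a step of an at least 1.8-fold higher number from compound 2 to compound 3 (0.27 log units; that floor lies within the scatter), a modest rise above the limit, though a second limit would not be surprising. The estimate for compound 3 is 3 ug/mL, with a range from 1.6 ug/mL to 8 ug/mL.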

Compound 3, solubility: 25 ug/mL
Estimate against measurement, compound 3: 8.3-fold (0.92 log units) below; measured number outside the range, above it.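

Putting pyridin-3-yl on the aromatic nitrogen gives a 12-fold higher number from compound 1 to compound 3 (1.08 log units; beyond the scatter) in this assay, so the group at this position can move the read-out far beyond the scatter, which the earlier, unresolved step could not show. Set against 4-(dimethylamino)phenyl, the same change gives an at least 15-fold higher number from compound 2 to compound 3 (1.19 log units; beyond the scatter), and that size is only a floor since compound 2 has a limit rather than a number of its own: the limit of < 1.6 ug/mL in this assay, at which 1 of the 3 values shown sits. The two compounds with a carbon-only ring on this nitrogen, compound 1 and compound 2, both read far lower than compound 3, whose ring holds one hetero atom, and no compound shown goes against this, though three compounds are a very small set.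

From the compounds shown here alone, what remains open is whether the ring nitrogen itself accounts for the rise, or whether simply removing the trifluoromethyl or dimethylamino group would do the same. An unsubstituted phenyl on this nitrogen would separate those two readings, and a pyridine joined through a different ring carbon would show whether the location of the ring nitrogen matters.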